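Aryl swap on the shared core: fluorophenyl to thiophenyl

A few compounds are considered here, and "the series" means these few. Any claim that something is new, unique, unknown or untested is made for them only; others in the source may bear on it.

Series notes. The two measured compounds share one core and differ only in the aryl group attached to it. Compound 1 `COc1ccc(-c2cn3ccnc3c(-c3ccc4ncn(C5CCCCC5)c4c3)n2)cc1` carries a methoxyphenyl group, and in a functional assay on HL-60 cells (Homo sapiens) for inhibition, read by sulforhodamine B assay, with a stated time of 48 h, tested at 10 uM (a higher number here means more inhibition at the concentration tested (going by the name of the read-out), a lower number less inhibition), compound 1 gives 98.6%. Compound 2 `Fc1ccc(-c2cn3ccnc3c(-c3ccc4ncn(C5CCCCC5)c4c3)n2)cc1` carries a fluorophenyl group, and in this assay compound 2 gives 2.03%, the lowest of the two numbers. For the measured compounds named here, the only measured step, a number 96.6 percentage points lower from compound 1 to compound 2 (beyond the scatter), shows that a change of the aryl group at this position can move the read-out across nearly its whole span.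

Compound 3 `c1cn2cc(-c3ccsc3)nc(-c3ccc4ncn(C5CCCCC5)c4c3)c2n1` is not yet measured; it differs from compound 2 in one place: thiophen-3-yl in place of 4-fluorophenyl on an aromatic carbon. Going by the values given here, no measured step involves a thiophen-3-yl group, so nothing bears on this change directly; the step of a number 96.6 percentage points lower from compound 1 to compound 2 (beyond the scatter) only shows that the aryl group here is decisive, without telling which way a new group will go. A move upward from compound 2 is held about as likely as a flat result, so the estimate sits low with a wide range. The estimated step is a number 33 percentage points higher from compound 2 to compound 3 (beyond the scatter). Compound 3 is expected to give about 35% in this assay, within a range of 3% to 85%.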

Compound 3, a percentage reported as inhibition, at one concentration (the size of the read-out at that concentration, not a potency): 18.5%
Estimate against measurement, compound 3: 16.5 percentage points above; the range from low to high includes it.
By their numbers in this assay, from the lowest: compound 2; then compound 3; then compound 1.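

Thiophen-3-yl in place of 4-fluorophenyl gives a number 16.5 percentage points higher from compound 2 to compound 3 (beyond the scatter) in this assay, so the low number of compound 2 is not the floor for every group other than 4-methoxyphenyl at this position, and with a five-membered aromatic ring with one sulfur atom the number is modestly higher. The gain remains small beside a number 80.1 percentage points lower from compound 1 to compound 3 (beyond the scatter), which is a large step and leaves 4-methoxyphenyl as the group with the highest number of the three at the concentration tested, while both the six-membered 4-fluorophenyl and the five-membered thiophen-3-yl stay far lower. No measurement at hand accounts for the differences among these three groups.

On these data alone, it remains open whether the high number of compound 1 belongs to the methoxy group specifically or would also be reached by other groups on the phenyl ring, such as 4-ethoxyphenyl, 4-hydroxyphenyl or 4-dimethylaminophenyl. As far as these compounds go, it is equally open whether a thiophene carrying a methoxy group, or a thiophen-2-yl group, would move the read-out any closer to that of compound 1.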